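The source may report more compounds than this note shows. Statements on the series, on what has been measured and on what is new or still open speak of the compounds shown alone.

Three compounds that share one core have values in a physicochemical assay for solubility (a lower number here means a less soluble compound, a higher number a more soluble compound), so far. Compound 1 `C[C@H](Oc1ccc(S(C)(=O)=O)cc1C(=O)N1Cc2ccc(C(F)(F)F)cc2C1)C(F)(F)F` gives 1 ug/mL in this measurement, compound 2 `COc1ccc2c(c1)CN(C(=O)c1cc(S(C)(=O)=O)ccc1O[C@@H](C)C(F)(F)F)C2` gives 46 ug/mL and compound 3 `Cc1cccc2c1CN(C(=O)c1cc(S(C)(=O)=O)ccc1O[C@@H](C)C(F)(F)F)C2` gives 73 ug/mL on the same scale. Compound 3 therefore lies within the scatter of compound 2 and far from compound 1. The next compound is compound 4 `C[C@H](Oc1ccc(S(C)(=O)=O)cc1C(=O)N1Cc2cccc(C#N)c2C1)C(F)(F)F`, and it differs from compound 3 by cyano in place of methyl on an aromatic carbon in one change: cyano in place of methyl on an aromatic carbon. Among the measured compounds shown here, only one measured step offers any guide, and a loose one. That step is a 46-fold higher number from compound 1 to compound 2 (1.66 log units; beyond the scatter) and it is large, but it swaps trifluoromethyl for methoxy and involves neither group at issue here. For the measured compounds named here, no measured step exchanges methyl or cyano, so the data fix no direction, and a shift beyond the scatter is not expected. The expected step is a 1.3-fold lower number from compound 3 to compound 4 (0.12 log units; within the scatter) with only a slight lean downward. For compound 4 the estimated value is 55 ug/mL and the expected range runs from 15 ug/mL to 150 ug/mL in this measurement.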

Compound 4, solubility: 259 ug/mL
Compound 4: the middle estimate sits 4.7-fold (0.67 log units) below what was measured, outside the stated range (above it).
By their numbers in this assay, from the lowest: compound 1; then compounds 2 and 3 (each within the scatter of the next); then compound 4.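

In this assay, exchanging methyl for cyano on this aromatic carbon, ortho to a fused ring and meta to a fused ring, gives a 3.5-fold higher number from compound 3 to compound 4 (0.55 log units; beyond the scatter), so the group at this position can move the number beyond the scatter. Among the compounds shown here, the earlier compounds could not show this, as their only step exchanged trifluoromethyl and methoxy and involved neither group at issue here. Nothing measured here bears on why the number rises with this change.

From the compounds shown here alone, it remains open whether other groups on this same carbon, such as an amine, a carboxylic acid or a longer chain, would shift the number in the same direction or as far. Also open, going by these compounds, is whether cyano would give a similar step on the carbon that carries methoxy in compound 2.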